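Hydroxymethyl Replaces an Ester Chain on the Shared Core

The source may report more compounds than this note shows. Statements on the series, on what has been measured and on what is new or still open speak of the compounds shown alone.

Compound 3 `CCOC(=O)COc1cc(=O)oc2cc(OCc3cccc(Cl)c3)ccc12` gives 1820 nM in an assay on isolated protein (strain Sprague-Dawley) for inhibition of Amine oxidase [flavin-containing] B (Rattus norvegicus), read by spectrophotometry, with a stated time of 5 min; on this read-out lower numbers stand for stronger inhibition and higher numbers for weaker inhibition. Among the three measured compounds it stands second highest: compound 1 `O=c1cc(O)c2ccc(OCc3cccc(F)c3)cc2o1` gives 2090 nM, and these two lie within the scatter of each other, whereas compound 2 `COc1cc(=O)oc2cc(OCc3cccc(F)c3)ccc12` gives 36.3 nM, far lower. Compound 4 `O=c1cc(CO)c2ccc(OCc3cccc(Cl)c3)cc2o1` differs from compound 3 in one place: hydroxymethyl in place of (ethoxycarbonyl)methoxy on an aromatic carbon. Among the compounds with values here, no measured step matches this change directly; the single measured step, a 58-fold lower number from compound 1 to compound 2 (1.76 log units; beyond the scatter), shows only that a small change on the shared core can move the number a great deal. Compound 4 keeps a hydrogen-bond donor, as compound 1 does, but loses the long chain. Compound 4 is therefore expected to give 600 nM, within a range of 100 nM to 4000 nM. The estimated step is a 3.0-fold lower number from compound 3 to compound 4 (0.48 log units; beyond the scatter).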

Compound 4, half-maximal inhibitory concentration: 5.25 nM
Compound 4: middle estimate off by 110-fold (2.06 log units), on the high side, and the stated range ends above it.
By their numbers in this assay, from the lowest: compound 4; then compound 2; then compounds 3 and 1 (each within the scatter of the next).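

In this assay, placing hydroxymethyl on this aromatic carbon instead of (ethoxycarbonyl)methoxy gives a 350-fold lower number from compound 3 to compound 4 (2.54 log units; beyond the scatter). This shows that replacing the ester chain with a much smaller group that carries a hydrogen-bond donor can lower the number sharply at this place on the shared core. No measurement shown explains the drop.

From the compounds shown here alone, it remains open whether losing the ester chain or gaining the hydroxyl matters more. A plain methyl, an aminomethyl or a carboxylic acid on this carbon could help separate the two.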